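The source may report more compounds than this note shows. Statements on the series, on what has been measured and on what is new or still open speak of the compounds shown alone.

Measured in an ADME assay for permeability, using PAMPA, at pH 4; on this read-out lower numbers stand for lower permeability and higher numbers for higher permeability:
- compound 1 `Cc1[nH]c2ccc(F)cc2c(=O)c1Br`: 16.2 10^-6 cm/s
- compound 2 `CCc1c(C)[nH]c2cc(OC)c(Cl)cc2c1=O`: 96.4 10^-6 cm/s
- compound 3 `CCc1c(C)[nH]c2cc(OC)c(Br)cc2c1=O`: 81.9 10^-6 cm/s

Compound 2 shares the top of this small set with compound 3, and compound 1 lies clearly lower. Compound 4 `COc1cc2[nH]c(C)c(Br)c(=O)c2cc1Cl`, not yet measured, differs from compound 2 by bromo in place of ethyl on an aromatic carbon.

Going by the values given here, no measured step makes this exact swap. Among the compounds with values here, the only step available, a 1.2-fold lower number from compound 2 to compound 3 (0.07 log units; within the scatter), puts bromo in place of chloro at a different place on the core, so it bears on this change only loosely. Compound 1 does carry bromo at the place that changes, and its value of 16.2 10^-6 cm/s hints at a downward move. However, compound 1 also differs from compound 2 elsewhere, so this is weak evidence. A moderate drop is therefore expected, with an estimated change of a 2.1-fold lower number from compound 2 to compound 4 (0.33 log units; beyond the scatter). For compound 4 the estimate is 45 10^-6 cm/s, with an expected range from 18 10^-6 cm/s to 100 10^-6 cm/s.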

Compound 4, apparent permeability: 125 10^-6 cm/s
Beside the measured number, compound 4's estimate is 2.8-fold (0.44 log units) below it, outside the stated range (above it).
By their numbers in this assay, from the lowest: compound 1; then compounds 3, 2 and 4 (each within the scatter of the next).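

In this assay, putting bromo in place of ethyl on this aromatic carbon, ortho to a methyl group, gives a 1.3-fold higher number from compound 2 to compound 4 (0.11 log units; within the scatter), so at this place the two groups cannot be told apart on this read-out. Going by these compounds alone, the earlier compounds held no pair differing only at this place, so this is the first direct reading of the change, and it shows that a chain of 2 heavy atoms can give way to a single bromine atom with no clear shift in the number. Nothing shown here offers an explanation for this result.

From the compounds shown here alone, only ethyl and bromo can be read at this place on the shared core, so what an amine, a carboxylic acid or a longer chain would give there remains open. Also open, going by these compounds, is whether the same swap would read the same way with different groups elsewhere on the core.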